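A urea becomes an amide: the step to compound 4

The source may hold more compounds than are shown below. What is called first, only, known or untested is meant among the compounds shown, and "the series" means these compounds.

Compound 2 `COc1cc(Cl)cc(-c2nn(-c3cccc(NC(=O)Nc4ccc(Cl)c(C(F)(F)F)c4)c3)cc2-c2ccncc2)c1` carries the methylated oxygen and the urea with the (4-chloro-3-(trifluoromethyl)phenyl)amino group. In a functional assay on Malme-3M cells (Homo sapiens) for inhibition, read by sulforhodamine B assay, with a stated time of 48 h, tested at 100 uM (a higher number here means a weaker effect of the compound at the concentration tested, a lower number a stronger effect), compound 2 gives -35%, the highest of the three numbers seen. Compound 3 `COc1cc(Cl)cc(-c2nn(-c3cccc(NC(=O)Nc4cc(C(F)(F)F)cc(C(F)(F)F)c4)c3)cc2-c2ccncc2)c1` gives -39% in this assay, within the scatter of compound 2, so no order between the two can be read. Going by the values given here, compound 1 `O=C(Nc1cccc(-n2cc(-c3ccncc3)c(-c3cc(O)cc(Cl)c3)n2)c1)Nc1ccc(Cl)c(C(F)(F)F)c1` gives -91% in this assay, and the step of a number 56 percentage points higher from compound 1 to compound 2 (beyond the scatter) is the only measured step; it concerns the methyl in place of hydrogen on an oxygen on an aromatic ring, far from the urea end.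

Compound 4 `COc1cc(Cl)cc(-c2nn(-c3cccc(NC(=O)c4cccc(C(F)(F)F)c4)c3)cc2-c2ccncc2)c1` differs from compound 2 at the carbonyl carbon: 3-(trifluoromethyl)phenyl in place of (4-chloro-3-(trifluoromethyl)phenyl)amino on a carbonyl carbon. The carbonyl thereby keeps one amide-type nitrogen and loses the other, so the urea becomes an amide. Among the compounds with values here, no measured step touches this part of the molecule, and the pair of compounds 2 and 3, which differ only in the aryl ring on the urea, shows two values within the scatter of each other. The expectation therefore rests on little, and a step of a number 15 percentage points higher from compound 2 to compound 4 (beyond the scatter) in this assay is estimated only as a broad guess.

For compound 4 the expected value in this assay is -20%, estimated within a range from -60% to 10%.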

Compound 4, a percentage reported as activity, at one concentration (the size of the read-out at that concentration, not a potency): 55%
Estimate against measurement, compound 4: 75 percentage points below, outside the stated range (above it).
By their numbers in this assay, from the lowest: compound 1; then compounds 3 and 2 (each within the scatter of the next); then compound 4.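

The carbonyl end of the molecule looked forgiving while compound 2 at -35% and compound 3 at -39% stood within the scatter of each other, but the urea-to-amide change gives a number 90 percentage points higher from compound 2 to compound 4 (beyond the scatter) in this assay and so shows that this position can matter a great deal. Since a higher number here means a weaker effect, the change takes away most of the effect seen at the concentration tested, and among the four compounds only compound 4 has a positive number. The swap is really two changes at once, as the group that leaves holds both a hydrogen-bond donor on its amino nitrogen and a chlorine, while 3-(trifluoromethyl)phenyl holds neither, and no measurement at hand accounts for the step.

An amide that keeps the chlorine, or a urea that lacks it, would show which of the two changes carries the step. Also open, from the compounds shown here alone, are how other links at this carbonyl end, such as a carbamate or a sulfonamide, would behave, and whether the amide would have the same effect alongside the free hydroxyl of compound 1.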